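The compounds below may be only part of what the source reports. "The series", "measured", "known", "first", "only" and "open" are said of these compounds alone.

Compound 1 `O=C(O)C(=O)/C=C(\O)c1cccc(Cl)c1` is the reference point for this step. In an assay for inhibition of kynurenine 3-monooxygenase (Rattus norvegicus) (on this read-out higher numbers stand for weaker inhibition and lower numbers for stronger inhibition), compound 1 gives 320 nM, the lowest of the two numbers in hand. Among the measured compounds shown here, its one measured neighbour is compound 2 `O=C(O)C(=O)/C=C(\O)c1cccc(F)c1`, which in this assay gives 580 nM; the step of a 1.8-fold higher number from compound 1 to compound 2 (0.26 log units; within the scatter), fluoro in place of chloro on an aromatic carbon, stays within the scatter. Compound 3 `O=C(O)C(=O)/C=C(\O)c1ccc(F)c(Cl)c1` keeps the chloro group of compound 1 and adds a second halogen: fluoro in place of hydrogen on an aromatic carbon. For the measured compounds named here, no measured pair shows the addition of a fluoro on the shared core, so the only step that bears on the change is the halogen swap, and that one indicates that exchanging one halogen for the other on this ring leaves the number essentially where it was. For compound 3 the expectation is therefore a step of a 1.1-fold lower number from compound 1 to compound 3 (0.03 log units; within the scatter), no larger than the scatter in either direction, because a 1.8-fold higher number from compound 1 to compound 2 (0.26 log units; within the scatter) gave nothing beyond it. The estimate for compound 3 in this assay is 300 nM, with a range from 120 nM to 800 nM, to be checked against the measured value.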

Compound 3, half-maximal inhibitory concentration: 270 nM
The estimate for compound 3 lay 1.1-fold (0.05 log units) above the measured number, within the range that was stated.
By their numbers in this assay, from the lowest: compounds 3, 1 and 2 (each within the scatter of the next, the first and the last beyond it).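

Among the compounds shown here, compound 3 is the first case in which a substituent is added to the ring of compound 1 rather than exchanged for another halogen. The fluoro sits on an aromatic carbon ortho to a chloro group and para to a group of 8 heavy atoms, and in this assay this addition gives a 1.2-fold lower number from compound 1 to compound 3 (0.07 log units; within the scatter). The earlier pair showed only the halogen swap, a 1.8-fold higher number from compound 1 to compound 2 (0.26 log units; within the scatter), whereas this step shows that the position can carry a fluoro alongside the chloro group with no change beyond the scatter, and nothing in hand accounts for this result.

The compounds shown leave open whether this position accepts anything larger than one fluorine, such as a methoxy group, an amine or a carboxylic acid, since hydrogen and fluoro are the only two substituents seen there. For the compounds shown here, they also leave open whether a fluoro at this place gives the same outcome on a ring without the chloro group, as the single addition step here has that chloro group present.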